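Hydroxyurea analogues: phenyl for propyl at two places

A few compounds are considered here, and "the series" means these few. Any claim that something is new, unique, unknown or untested is made for them only; others in the source may bear on it.

Measured compounds:
compound 1 `CCCCCCOc1ccc2c(c1)C=C(CN(O)C(N)=O)CO2` — 340 nM
compound 2 `NC(=O)N(O)CC1=Cc2cc(OCCCc3ccccc3)ccc2OC1` — 160 nM
compound 3 `CCCCNC(=O)N(O)CC1=Cc2cc(Oc3ccccc3)ccc2OC1` — 69 nM

These three compounds were tested in an assay (Cavia porcellus) for inhibition of Polyunsaturated fatty acid 5-lipoxygenase (Homo sapiens); a lower number here means a stronger inhibitor, a higher number a weaker inhibitor. Compound 1 and compound 2 differ in one place: phenyl in place of propyl on a saturated chain carbon, three bonds along the chain from an oxygen on an aromatic ring. That change gave a 2.1-fold lower number from compound 1 to compound 2 (0.33 log units; beyond the scatter). Compound 3 gives the lowest number of the three; how the core of compound 3 differs from the core of compound 1 is not broken down here.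

Compound 4 `O=C(NCc1ccccc1)N(O)CC1=Cc2cc(Oc3ccccc3)ccc2OC1` has not yet been measured. It differs from compound 3 in one place: phenyl in place of propyl on a saturated chain carbon bound to an amide-type nitrogen. Within the data shown here, this is the same kind of change as the one from compound 1 to compound 2, but at a different place: there the carbon was three bonds along the chain from an oxygen on an aromatic ring, here it is bound to an amide-type nitrogen. A step of similar size is expected, a 1.5-fold lower number from compound 3 to compound 4 (0.19 log units; within the scatter), resting on the step from compound 1 to compound 2, a 2.1-fold lower number from compound 1 to compound 2 (0.33 log units; beyond the scatter), though the different place makes this uncertain. Compound 4 is therefore estimated at 45 nM, with a range from 15 nM to 150 nM.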

Compound 4, half-maximal inhibitory concentration: 440 nM
Estimate against measurement, compound 4: 9.8-fold (0.99 log units) below, and the stated range ends below it.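

In this assay, placing phenyl for propyl on the chain carbon bound to an amide-type nitrogen gave a 6.4-fold higher number from compound 3 to compound 4 (0.80 log units; beyond the scatter), so compound 4 is a weaker inhibitor than compound 3. Set beside the earlier step, the same change does not carry over from one core to the other in size or direction: the same change on two cores in this assay, a 2.1-fold lower number (0.33 log units; beyond the scatter) from compound 1 to compound 2 and a 6.4-fold higher number (0.80 log units; beyond the scatter) from compound 3 to compound 4, 14-fold (1.13 log units) apart, beyond the scatter of two such steps. These two pairs do not show whether the core or the place of the change accounts for the gap, since both differ between them, and they show no general rule for this series.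

On these data alone, it remains open how a phenethyl or cyclohexylmethyl group on that amide-type nitrogen would compare with the butyl of compound 3 and the benzyl of compound 4.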